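The source may hold more compounds than are shown below. What is called first, only, known or untested is meant among the compounds shown, and "the series" means these compounds.

Measured so far:
- compound 1 `COc1ccc(OC)c(C2CC(c3ccccn3)=NN2c2ccccc2)c1`: 27%
- compound 2 `COc1ccc(OC)c(C2CC(c3ccccn3)=NN2)c1`: 15%
- compound 3 `COc1ccc(OC)c(-c2nc(-c3cnccn3)no2)c1`: 11%

In a functional assay on the whole organism (strain Charles Foster albino) for inhibition, with Rattus norvegicus as the target, read by paw edema, with stated times of 30 min and 3 h, at a dose of 50 mg/kg by the oral route (on this read-out lower numbers stand for less inhibition and higher numbers for more inhibition at the one dose given (going by the name of the read-out)), compound 2 gives 15%, second highest of the three numbers, though compound 3 lies within the scatter of it; only compound 1 stands apart, the step being a number 12 percentage points lower from compound 1 to compound 2 (beyond the scatter) for hydrogen in place of phenyl on the ring amine nitrogen. Compound 4 `COc1ccc(OC)c(C2CC(c3cccnc3)=NN2)c1` differs from compound 2 by pyridin-3-yl in place of pyridin-2-yl on a carbon with a double bond to nitrogen. Among the measured compounds shown here, no measured step touches the pyridyl; the one step on record, a number 12 percentage points lower from compound 1 to compound 2 (beyond the scatter), concerns a different part of the core, so it gives no direction for this change. The expectation is therefore a step of no size beyond the scatter, no change at the digits printed from compound 2 to compound 4 (within the scatter). Compound 4 is estimated at 15%, with a range from 4% to 28%.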

Compound 4, a percentage reported as inhibition, in the whole organism at one dose (the size of the read-out at that dose, not a potency): 15%
For compound 4 middle estimate and measured number coincide at the digits printed; low and high end bracket the measured number.
By their numbers in this assay, from the lowest: compounds 3, 2 and 4 (each within the scatter of the next); then compound 1.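

In this assay, among the compounds shown here, pyridin-3-yl in place of pyridin-2-yl on the carbon with a double bond to nitrogen gives no change at the digits printed from compound 2 to compound 4 (within the scatter), the first reading at this position. At this one dose, the read-out does not separate the two pyridyl attachments, so this change leaves the number where it stands on the unsubstituted ring nitrogen. No supporting measurement bears on this result.

Still open, on these data alone, is whether pyridin-4-yl, or a carboxylic acid or an amine on a phenyl at this carbon, would read differently. Also open, as far as these compounds go, is how pyridin-3-yl behaves with phenyl on the ring nitrogen.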